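This account rests on a few compounds, and the source may have more. Where it says the series, first, only, none or still open, it means among the compounds named here.

Compound 1, `CCCC(=O)N1CCC(NS(=O)(=O)c2ccc(NC(=O)c3ccc(CC)cc3)c3ccccc23)CC1`, gives 10.8 nM in an in vitro functional assay on CHO/Galpha16 cells for antagonist activity at C-C chemokine receptor type 8 (Homo sapiens), read by FLIPR; on this read-out higher numbers stand for weaker inhibition and lower numbers for stronger inhibition.
Compound 2, `CCCCc1ccc(C(=O)Nc2ccc(S(=O)(=O)NC3CCN(C(=O)CCC)CC3)c3ccccc23)cc1`, gives 15.3 nM in this assay.
Compound 3, `CCCC(=O)N1CCC(NS(=O)(=O)c2ccc(NC(=O)c3ccoc3)c3ccccc23)CC1`, gives 1520 nM in this assay.

Compound 3 stands at the highest number of the three: the step of a 99-fold higher number from compound 2 to compound 3 (2.00 log units; beyond the scatter) and the step of a 140-fold higher number from compound 1 to compound 3 (2.15 log units; beyond the scatter) are both large and beyond the scatter, so compound 3 is the weakest inhibitor shown. Compound 4, `CCCC(=O)N1CCC(NS(=O)(=O)c2ccc(NC(=O)c3cccnc3)c3ccccc23)CC1`, differs from compound 3 by pyridin-3-yl in place of furan-3-yl on a carbonyl carbon.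

Going by the values given here, no measured step compares these two groups directly. The two steps that bear on the carbonyl substituent, a 140-fold higher number from compound 1 to compound 3 (2.15 log units; beyond the scatter) and a 99-fold higher number from compound 2 to compound 3 (2.00 log units; beyond the scatter), show that a six-membered aromatic ring at that position gives a far lower number than furan-3-yl, though in both cases the ring carried an alkyl chain and had no ring nitrogen. On that basis the move to pyridin-3-yl is expected to lower the number, with the step of a 6.1-fold lower number from compound 3 to compound 4 (0.78 log units; beyond the scatter) expected. The uncertainty is wide because compound 3 gives 1520 nM and the shift from there may not reach the level of compound 1 or compound 2. Compound 4 is therefore estimated at 250 nM, within a range of 40 nM to 1500 nM.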

Compound 4, half-maximal inhibitory concentration: 885 nM
Estimate against measurement, compound 4: 3.5-fold (0.55 log units) below; the range from low to high includes it.
By their numbers in this assay, from the lowest: compounds 1 and 2 (each within the scatter of the next); then compounds 4 and 3 (each within the scatter of the next).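

In this assay, pyridin-3-yl in place of furan-3-yl on the carbonyl carbon gave only a 1.7-fold lower number from compound 3 to compound 4 (0.23 log units; within the scatter), so the two rings cannot be told apart here. The other two steps stay large, at a 58-fold higher number from compound 2 to compound 4 (1.76 log units; beyond the scatter) and an 82-fold higher number from compound 1 to compound 4 (1.91 log units; beyond the scatter), which shows that a six-membered aromatic ring at this position does not by itself reach the numbers of the 4-ethylphenyl and 4-butylphenyl compounds. Nothing available gives a reason for this gap.

From the compounds shown here alone, what a plain phenyl on the carbonyl carbon would give remains open, and with it whether the gap follows the ring nitrogen or the missing alkyl chain. Also open, going by these compounds, is whether a methoxy group or a chlorine on that phenyl could take the place of the ethyl or butyl chain.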